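The source may report more compounds than this note shows. Statements on the series, on what has been measured and on what is new or still open speak of the compounds shown alone.

Working notes on the series. Compound 1 `C=C(C)C(=O)NCCOc1ccc(Oc2c(-c3ccc(F)cc3)sc3cc(O)ccc23)cc1` is the starting point. In a functional assay on Ishikawa cells (Homo sapiens) for antiproliferative activity, read by CCK-8 assay, with a stated time of 48 h (a lower number here means a stronger inhibitor, a higher number a weaker inhibitor), compound 1 gives > 25000 nM, which is a limit of the assay and not a number. Compound 2 `O=C(CCCNCCOc1ccc(Oc2c(-c3ccc(F)cc3)sc3cc(O)ccc23)cc1)N1CCC1` likewise gives > 25000 nM in this assay, again a limit. Compound 3 `O=C(/C=C/CNCCOc1ccc(Oc2c(-c3ccc(F)cc3)sc3cc(O)ccc23)cc1)N1CCC1` gives 6560 nM in this assay. Of the measured steps, a step that the two limits leave unreadable from compound 1 to compound 2, whereas an at least 3.8-fold lower number from compound 1 to compound 3 (0.58 log units; beyond the scatter) and an at least 3.8-fold lower number from compound 2 to compound 3 (0.58 log units; beyond the scatter); the sizes of both readable steps are bounded by the limit of > 25000 nM in this assay, at which 2 of the 3 values shown sit.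

Compound 4 `C=CC(=O)N1CC(Oc2ccc(Oc3c(-c4ccc(F)cc4)sc4cc(O)ccc34)cc2)C1` carries the change (1-(vinylcarbonyl)azetidin-3-yl in place of 2-(((1-methylethenyl)carbonyl)amino)ethyl on an oxygen on an aromatic ring). For the measured compounds named here, no measured step covers this change directly. The step from compound 1 to compound 3 and the step from compound 2 to compound 3 show that an ethenyl-carbonyl amide in the side chain can bring the number down from the limit, while compound 1 and compound 2 show that amide side chains of this kind can also stay at the limit. A modest lowering is therefore expected, with wide uncertainty. For compound 4 the expected value in this assay is 10000 nM, with a range from 2500 nM to 30000 nM. The expected step is an at least 2.5-fold lower number from compound 1 to compound 4 (0.39 log units; beyond the scatter).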

Compound 4, half-maximal inhibitory concentration: 12300 nM
For compound 4 the middle estimate is 1.2-fold (0.09 log units) below the measured one, and the stated range covers the measured number.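

In this assay, the steps of an at least 2.0-fold lower number from compound 1 to compound 4 (0.30 log units; that floor lies within the scatter) and an at least 2.0-fold lower number from compound 2 to compound 4 (0.30 log units; that floor lies within the scatter) are floors only, so neither establishes a real gain from 1-(vinylcarbonyl)azetidin-3-yl on this oxygen: the limit of > 25000 nM in this assay, at which 2 of the 4 values shown sit.

The comparison that can be read in full is a 1.9-fold higher number from compound 3 to compound 4 (0.27 log units; within the scatter), which gives no ranking of the two side chains. For the compounds shown here, on this oxygen, a side chain holding a four-membered non-aromatic ring therefore gives a value within the scatter of compound 3, the only earlier compound with a value that is not a limit.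

On these data alone, it remains open whether the double bond of the vinylcarbonyl matters on the azetidine, which a propanoyl group there would test. Also open, as far as these compounds go, is whether a pyrrolidine ring in place of the azetidine would keep the number in this range.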